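The source may hold more compounds than are shown below. What is called first, only, known or untested is meant among the compounds shown, and "the series" means these compounds.

Measured compounds:
Compound 1, `CCCSc1nc(Cl)c2c(n1)N(Cc1ccccc1)C(C(=O)NCCC1=CCc3ccccc31)N2`, reads 30000 nM
Compound 2, `CCCSc1nc(Cl)c2c(n1)N(Cc1ccco1)C(C(=O)N1CCN(C)CC1)N2`, reads 35000 nM

Both numbers come from a functional assay on TE-1 cells (Homo sapiens) for antiproliferative activity, read by MTT assay, with a stated time of 72 h; on this read-out lower numbers stand for stronger inhibition and higher numbers for weaker inhibition. Compound 1 gives the lower of the two readings, but its gap to compound 2 lies within the scatter of repeated measurement, so the two cannot be told apart on these figures; both sit at the weak end of what this assay reports. They share the same core and differ in more than one place at once, so no single change between them is isolated.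

Compound 3, `CCCSc1nc(Cl)c2c(n1)N(Cc1ccccc1)C(C(=O)NCCCc1ccccc1)N2`, has not yet been measured. It keeps the benzyl of compound 1 on the core and changes only the amide side: a group of 7 heavy atoms (7 carbon; one six-membered aromatic ring of carbon only) in place of a group of 9 heavy atoms (9 carbon; one five-membered non-aromatic ring of carbon only, one six-membered aromatic ring of carbon only), on a saturated chain carbon, two bonds along the chain from an amide-type nitrogen. Among the compounds with values here, no measured pair isolates such a change, so the size of the step has to be estimated. Compound 1 at 30000 nM and compound 2 at 35000 nM differ in the amide part and still read within the scatter of each other, which gives no sign of a large shift from this region. The step from compound 1 to compound 3 is therefore expected to be no change at the digits printed from compound 1 to compound 3 (within the scatter), not beyond the scatter. Compound 3 is estimated at 30000 nM, within a range from 10000 nM to 90000 nM.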

Compound 3, half-maximal inhibitory concentration: 23000 nM
Beside the measured number, compound 3's estimate is 1.3-fold (0.12 log units) above it; measured number inside the range.
By their numbers in this assay, from the lowest: compounds 3, 1 and 2 (each within the scatter of the next).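

The pair of compound 1 and compound 3 gives the first view of a single change at this position: in this assay, putting benzyl in place of the group with a five-membered non-aromatic ring and a six-membered aromatic ring, on a saturated chain carbon, two bonds along the chain from an amide-type nitrogen, gives a 1.3-fold lower number from compound 1 to compound 3 (0.12 log units; within the scatter) and so stays within the scatter. On this read-out, then, the two compounds cannot be told apart, even though the five-membered non-aromatic ring and the double bond outside aromatic rings are gone in compound 3. Nothing measured here speaks to why this step is so small.

Going by these compounds, this single step compares two groups made only of carbon, so it remains open whether an amine, a carboxylic acid or a longer chain at the same place would give a step beyond the scatter. The benzyl on the shared core also stays fixed in this pair, which leaves the contribution of that group unresolved, and a pyridine ring in its place would be a separate question.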